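Trimethoxyphenyl amide series: phenoxy replaced by sulfonamide

The source may report more compounds than this note shows. Statements on the series, on what has been measured and on what is new or still open speak of the compounds shown alone.

Measured compounds:
compound 1 `COc1ccc(CN(C(=O)Cn2cc(COc3ccccc3)nn2)c2cc(OC)c(OC)c(OC)c2)cc1` gives 12500 nM
compound 2 `COc1ccc(CN(C(=O)Cn2cc(Cn3ccc4ccccc43)nn2)c2cc(OC)c(OC)c(OC)c2)cc1` gives 42600 nM

Going by the values given here, in a functional assay on MGC-803 cells (Homo sapiens) for antiproliferative activity, read by MTT assay, with a stated time of 48 h (on this read-out higher numbers stand for weaker inhibition and lower numbers for stronger inhibition), compound 1 holds the lowest of the two numbers so far. Among the compounds with values here, compound 2 is the nearest neighbour, and the one recorded step, a 3.4-fold higher number from compound 1 to compound 2 (0.53 log units; beyond the scatter), already shows the effect of trading the phenoxy for a larger ring-bearing group at the same position.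

Compound 3 `COc1ccc(CN(C(=O)Cn2cc(CNS(=O)(=O)c3ccc(C)cc3)nn2)c2cc(OC)c(OC)c(OC)c2)cc1` has not yet been run. Its change from compound 1 is ((4-methylphenyl)sulfonyl)amino in place of phenoxy on a saturated chain carbon bound to an aromatic carbon. Within the data shown here, the only step that speaks to this position is the one from compound 1 to compound 2: a modest weakening when the phenoxy gave way to a bulkier group. Among the measured compounds shown here, the entering group here is likewise larger than the phenoxy it replaces, though it also adds a hydrogen-bond donor and a second acceptor, for which no measured step exists.

On that basis compound 3 is expected to be weaker than compound 1 or about the same, with the step estimated at a 1.8-fold higher number from compound 1 to compound 3 (0.25 log units; within the scatter). The estimate for compound 3 is 22000 nM, expected to fall between 7000 nM and 65000 nM.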

Compound 3, half-maximal inhibitory concentration: 1580 nM
Compound 3: middle estimate off by 14-fold (1.14 log units), on the high side, and the stated range ends above it.
By their numbers in this assay, from the lowest: compound 3; then compound 1; then compound 2.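

In this assay, this place on the saturated chain carbon bound to an aromatic carbon proves able to give a stronger result as well as a weaker one: ((4-methylphenyl)sulfonyl)amino in place of phenoxy gives a 7.9-fold lower number from compound 1 to compound 3 (0.90 log units; beyond the scatter) and the same group in place of 1H-indol-1-yl gives a 27-fold lower number from compound 2 to compound 3 (1.43 log units; beyond the scatter) in this series. Together with a 3.4-fold higher number from compound 1 to compound 2 (0.53 log units; beyond the scatter) this shows that a simple rule of larger entering groups giving weaker inhibition does not hold: compound 3 goes against it, with more heavy atoms than the phenoxy of compound 1 and the lowest number of the three. Nothing available accounts for the difference between these groups.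

Still open is which part of the ((4-methylphenyl)sulfonyl)amino group carries the step, since the compounds shown do not separate the sulfonyl, the amino hydrogen and the 4-methylphenyl ring from one another. A methylsulfonylamino group, a phenylsulfonylamino group without the methyl, or a benzoylamino group at the same place would address that question directly.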